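This account rests on a few compounds, and the source may have more. Where it says the series, first, only, none or still open, it means among the compounds named here.

Measured compounds:
- compound 1, `COc1ccc(/C=C\c2cc(O)cc(O)c2)cc1N`: 40000 nM
- compound 2, `COc1ccc(/C=C/c2cc(O)cc(O)c2)cc1N`: 80000 nM
- compound 3, `COc1cc(/C=C\c2ccc(O)c(O)c2)cc(OC)c1`: 50 nM

Of these three, compound 3 stands lowest in a functional assay on HL-60 cells (Homo sapiens) for inhibition; a higher number here means a weaker inhibitor, a lower number a stronger inhibitor: its number sits well apart from both others, and both gaps are beyond the scatter. Compound 3 gives 50 nM, whereas compound 1 gives 40000 nM and compound 2 gives 80000 nM.

Compound 4, `COc1cc(/C=C/c2ccc(O)c(O)c2)cc(OC)c1`, has not yet been measured in this assay. It differs from compound 3 as follows: the two compounds have the same atoms and bonds and differ only in configuration as drawn: 1 of 1 stereo elements differ; a double bond is drawn Z in compound 3 and E in compound 4.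

Among the measured compounds shown here, only one measured step is of the same kind, and it bears directly on this change because of the fact that compounds 1 and 2 differ only in the configuration as drawn. That step gave a 2.0-fold higher number from compound 1 to compound 2 (0.30 log units; within the scatter), so turning the drawn double bond from Z to E left the number where it was, within the usual spread of repeats. On that basis the step from compound 3 to compound 4 in this assay is expected to be small as well, if anything toward a higher number, but a single comparison is a thin base and the true size is uncertain; compound 4 is therefore estimated with a wide range.

For compound 4 the expected value in this assay is 300 nM, between 50 nM and 5000 nM, which corresponds to an expected step of a 6.0-fold higher number from compound 3 to compound 4 (0.78 log units; beyond the scatter).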

Compound 4, half-maximal inhibitory concentration: 800 nM
Estimate against measurement, compound 4: 2.7-fold (0.43 log units) below; the range from low to high includes it.
By their numbers in this assay, from the lowest: compound 3; then compound 4; then compounds 1 and 2 (each within the scatter of the next).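

In this assay, the drawn configuration of the double bond turns out to matter a great deal for this pair: a 16-fold higher number from compound 3 to compound 4 (1.20 log units; beyond the scatter). The earlier pair gave a 2.0-fold higher number from compound 1 to compound 2 (0.30 log units; within the scatter), so the same Z to E change can leave the number in place for one pair of compounds and raise it sharply for another. With only two such pairs, this shows that the size of the step depends on the rest of the molecule, and the change can be read on its own here, as nothing else separates the two structures: the fact that compounds 3 and 4 differ only in the configuration as drawn

Compounds 1 and 2 differ from compounds 3 and 4 in more than one place, so the compounds shown do not tell which group sets the size of the step. They also leave open whether the Z to E step would stay this large with a group such as a carboxylic acid or a longer chain on the core of compound 3.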